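Swapping methoxy for methyl on a coumarin-imidazole inhibitor

The compounds below may be only part of what the source reports. "The series", "measured", "known", "first", "only" and "open" are said of these compounds alone.

Of the compounds shown here, three sharing one core have been tested in an assay on V79MZh11B2 cells for inhibition of cytochrome P450 11B2, mitochondrial (Homo sapiens), read by HPLC, with a stated time of 25 min; on this read-out lower numbers stand for stronger inhibition and higher numbers for weaker inhibition. Compound 1 `CC(C)Oc1ccc(COc2ccc3c(Cn4ccnc4)cc(=O)oc3c2)cc1` gives 82 nM. Compound 2 `COc1cccc(COc2ccc3c(Cn4ccnc4)cc(=O)oc3c2)c1` gives 127 nM. Compound 3 `COc1ccc(COc2ccc3c(Cn4ccnc4)cc(=O)oc3c2)cc1OC` gives 82 nM. Compound 2 shows the highest of the three numbers, but its gaps to compound 1 and to compound 3 are each within the usual scatter of this kind of measurement, so the three cannot be told apart with confidence. Among the compounds with values here, the only single-point step among them is a 1.5-fold lower number from compound 2 to compound 3 (0.19 log units; within the scatter), which adds a methoxy on an aromatic carbon and stays within the scatter.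

Compound 4 `Cc1cccc(COc2ccc3c(Cn4ccnc4)cc(=O)oc3c2)c1` has not yet been measured. It differs from compound 2 as follows: methyl in place of methoxy on an aromatic carbon. Within the data shown here, no measured step trades a methoxy for a methyl, so the closest guidance is that the one change made to compound 2 so far, the addition of a methoxy, did not move the number beyond the scatter. Small changes on this outer ring therefore appear, on this small set, to leave the readout roughly where it was.

On that basis compound 4 is expected to stay close to compound 2, with an estimated step of a 1.0-fold higher number from compound 2 to compound 4 (0.01 log units; within the scatter) in this assay. The estimate for compound 4 is 130 nM, with a likely range from 55 nM to 310 nM.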

Compound 4, half-maximal inhibitory concentration: 250 nM
Estimate against measurement, compound 4: 1.9-fold (0.28 log units) below, and the stated range covers the measured number.
By their numbers in this assay, from the lowest: compounds 1, 3, 2 and 4 (each within the scatter of the next, the first and the last beyond it).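

In this assay, within the data shown here, the change from 3-methoxyphenyl to 3-methylphenyl gives a 2.0-fold higher number from compound 2 to compound 4 (0.29 log units; within the scatter), and this is the first direct exchange of one group for another at this place, on an aromatic carbon meta to a large group. The swap takes away an oxygen and a hydrogen-bond acceptor, yet the step stays within the scatter, so this single pair gives no firm sign that the methoxy oxygen matters here, although it cannot rule out a real difference either. The data offer no independent measurement that could explain the size of this step.

What remains open is whether any group at this carbon can move the number clearly beyond the scatter, since only methoxy and methyl are shown there, and an amine, a carboxylic acid or a longer chain such as butoxy could behave quite differently. It is also unknown whether the same exchange of methoxy for methyl would give a similar step on another carbon of this ring or on a different compound of the series.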